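A Chloro-for-Methoxy Swap Tried on a Second Core

A few compounds are considered here, and "the series" means these few. Any claim that something is new, unique, unknown or untested is made for them only; others in the source may bear on it.

Compound 1 `COc1cncc(C2=CC3CC(C2)CN(C)C3)c1` and compound 2 `CN1CC2C=C(c3cncc(Cl)c3)CC(C2)C1` share one core and differ in a single place: chloro in place of methoxy on an aromatic carbon. In an in vitro assay on SH-SY5Y cells for displacement of a labelled ligand from Neuronal acetylcholine receptor; alpha3/beta4 (Homo sapiens) (on this read-out higher numbers stand for weaker inhibition and lower numbers for stronger inhibition), compound 1 gives 596 nM, and compound 2 gives 1830 nM, so the swap produced a 3.1-fold higher number from compound 1 to compound 2 (0.49 log units; beyond the scatter). Compound 3 `COc1ccc(C2=CC3CC(C2)CN(C)C3)cn1` is built from the same atoms as compound 1, joined differently; the difference between the two cores is not broken down here. In this assay compound 3 reaches only a limit, > 10000 nM. Compound 4 `CN1CC2C=C(c3ccc(Cl)nc3)CC(C2)C1` has not yet been measured. It stands to compound 3 as compound 2 stands to compound 1: chloro in place of methoxy on an aromatic carbon. The surroundings are not identical. The chloro now sits next to the ring nitrogen and para to a large group rather than two atoms from the ring nitrogen and meta to a large group, so this is the same kind of change, not the same change. Compound 3 already sits at the limit of > 10000 nM in this assay, at which 1 of the 3 values shown sits. The earlier swap gave a 3.1-fold higher number from compound 1 to compound 2 (0.49 log units; beyond the scatter). Compound 4 is therefore expected to remain a limit as well, a step that the limit leaves unreadable from compound 3 to compound 4. The estimate for compound 4 in this assay is 30000 nM, lying between 10000 nM and 100000 nM.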

Compound 4, inhibition constant: 986 nM
The estimate for compound 4 lay 30-fold (1.48 log units) above the measured number; the whole stated range lies above it.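

Moving the swap to the core of compound 3 gave an at least 10-fold lower number from compound 3 to compound 4 (1.00 log units; beyond the scatter), whereas on the core of compound 1 the same swap raised the number. The change therefore did not carry over from one core to the other in this assay, either in direction or in size: the same change on two cores in this assay, a 3.1-fold higher number (0.49 log units; beyond the scatter) from compound 1 to compound 2 and an at least 10-fold lower number (1.00 log units; beyond the scatter) from compound 3 to compound 4, at least 31-fold (1.49 log units) apart, beyond the scatter of two such steps. Going by these compounds, these two pairs show that the outcome of this swap cannot be assumed to transfer between the two cores, but they do not show which difference between the cores is responsible, and the exact size of the new step stays unknown, as compound 3 carries a limit and not a number.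

The compounds shown carry only methoxy or chloro on the aromatic ring, so it remains open how an amine, a nitrile or a longer alkoxy chain would behave at these places. Also open, on these data alone, is whether the opposite steps would persist if an ethyl group replaced the methyl on the nitrogen of the shared core.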